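Chloro in place of methoxy on the shared core

This account rests on a few compounds, and the source may have more. Where it says the series, first, only, none or still open, it means among the compounds named here.

Compound 1 `OC[C@H]1O[C@@H](n2c(Cl)c(-c3ccsc3)c3cc(Cl)c(Cl)cc32)C[C@@H]1O` is the other member of the series; in a functional assay on KB cells (Homo sapiens) for cytotoxicity, read by spectrophotometry and crystal violet staining (on this read-out higher numbers stand for weaker inhibition and lower numbers for stronger inhibition), compound 1 gives 50000 nM. Compound 2 `COc1c(C#N)c2cc(Cl)c(Cl)cc2n1[C@H]1C[C@H](O)[C@@H](CO)O1` differs from it in several places, so the two are not a single step and are read only for what their own values show. In this assay compound 2 gives no number but a limit, > 100000 nM. Compound 2 therefore sits at the limit of > 100000 nM in this assay, at which 1 of the 2 values shown sits. Compound 3 `N#Cc1c(Cl)n([C@H]2C[C@H](O)[C@@H](CO)O2)c2cc(Cl)c(Cl)cc12` is compound 2 with chloro in place of methoxy on an aromatic carbon. Among the measured compounds shown here, no measured step supports the change, so the expected step of an at least 1.2-fold lower number from compound 2 to compound 3 (0.09 log units; that floor lies within the scatter) is estimated as small, leaning toward stronger inhibition but probably not beyond the scatter. Compound 3 is expected to give about 80000 nM in this assay, between 30000 nM and 200000 nM, with a real chance that only a limit is returned.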

Compound 3, half-maximal inhibitory concentration: 60000 nM
Beside the measured number, compound 3's estimate is 1.3-fold (0.12 log units) above it; measured number inside the range.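

Chloro in place of methoxy on the aromatic carbon next to the ring nitrogen turns a limit into a measured number in this assay: an at least 1.6-fold lower number from compound 2 to compound 3 (0.22 log units; that floor lies within the scatter), so the size of this change stays unfixed and its floor does not pass the scatter. Cyano in place of thiophen-3-yl on an aromatic carbon gives a 1.2-fold higher number from compound 1 to compound 3 (0.08 log units; within the scatter), so these two groups are not separated in this assay. Compound 2 stands as a limit, not a number: the limit of > 100000 nM in this assay, at which 1 of the 3 values shown sits.

The compounds shown leave open whether any group at either place moves the value in this assay clearly beyond the scatter. An amine or a carboxylic acid on the carbon next to the ring nitrogen would test this place with a group other than methoxy or chloro.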